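Thioether Propargylamines: From Methoxy to Trifluoromethyl

A few compounds are considered here, and "the series" means these few. Any claim that something is new, unique, unknown or untested is made for them only; others in the source may bear on it.

Compound 1 `C#CCNC1CCc2c(SCc3ccc(Cl)cc3Cl)cccc21`: 22300 nM
Compound 2 `C#CCNC1CCc2c(SCc3cccc(OC)c3)cccc21`: 1520 nM
Compound 3 `C#CCNC1CCc2c(OCc3cccc(C(F)(F)F)c3)cccc21`: 5410 nM

Of the compounds shown here, three built on a shared core have been tested in an ADME assay on isolated protein for inhibition of Amine oxidase [flavin-containing] B (Homo sapiens); a higher number here means a weaker inhibitor, a lower number a stronger inhibitor. Compound 2 gives the lowest of the three numbers, at 1520 nM. Its nearest neighbour is compound 3, whose value of 5410 nM lies beyond the scatter, and compound 1, at 22300 nM, stands furthest away. For the measured compounds named here, with three compounds differing from one another in more than one place, no single step between measured pairs can be isolated.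

The next compound to be examined is compound 4 `C#CCNC1CCc2c(SCc3cccc(C(F)(F)F)c3)cccc21`. It is derived from compound 2 by a change at one position: trifluoromethyl in place of methoxy on an aromatic carbon. The same trifluoromethyl group appears in compound 3, but there it sits on an ether-linked benzyl group, so the two compounds cannot be compared directly.

Because compound 3 gives 5410 nM and carries the same trifluoromethyl group, a modest weakening from compound 2 is expected, and the step of a 2.0-fold higher number from compound 2 to compound 4 (0.30 log units; within the scatter) is estimated to be small but possibly beyond the scatter. The estimate for compound 4 in this assay is 3000 nM, with a plausible range from 900 nM to 10000 nM.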

Compound 4, half-maximal inhibitory concentration: 7710 nM
For compound 4 the middle estimate is 2.6-fold (0.41 log units) below the measured one; the range from low to high includes it.
By their numbers in this assay, from the lowest: compound 2; then compounds 3 and 4 (each within the scatter of the next); then compound 1.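

In this assay, trifluoromethyl in place of methoxy on an aromatic carbon gives the first change at a single place among these compounds, and it brings a 5.1-fold higher number from compound 2 to compound 4 (0.71 log units; beyond the scatter). The position therefore responds to what is placed on it, and within this pair the lower number belongs to the methoxy compound, so compound 2 keeps the lowest number of the four while compound 3 and compound 4 lie within the scatter of each other. No measurement at hand accounts for the size of this step, and nothing shown ties it to a particular feature of either group.

The compounds shown leave open how a hydroxyl group, an amine or a single chlorine would fare at this same place, and so whether methoxy is unusually favourable or trifluoromethyl unusually poor there. They also leave open whether the same exchange would give a step of similar size on the ether-linked benzyl group of compound 3, since a methoxy partner for that compound is not among them.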